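Swapping a thiophene for a pyridine on the carbonyl

The compounds below may be only part of what the source reports. "The series", "measured", "known", "first", "only" and "open" are said of these compounds alone.

Compound 1 `COC(=O)/C=C1\Nc2ncccc2OC1=O` shares its core with the two other compounds described here. In an ADME assay on Vero cells (Chlorocebus sabaeus) for cytotoxicity, read by MTT assay, with a stated time of 72 h (a lower number here means that less compound is tolerated, a higher number that more compound is tolerated), compound 1 has "not determined" (no result reported), so no number exists for it. Compound 2 `O=C1Oc2ccccc2N/C1=C\C(=O)c1cccs1` was tested, and in this assay compound 2 reaches only a limit of the assay, > 1840000 nM, which is not a measured number. For the measured compounds named here, of the two entries, this places compound 2 at the limit of > 1840000 nM in this assay, at which 1 of the 2 values shown sits; the other entry carries no single number, so no step between measured compounds can be drawn, and nothing tells how large a change a structural edit produces.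

Compound 3 `O=C1Oc2ccccc2N/C1=C\C(=O)c1ccncc1` differs from compound 2 in one place: pyridin-4-yl in place of thiophen-2-yl on a carbonyl carbon, in words pyridin-4-yl in place of thiophen-2-yl on a carbonyl carbon. Going by the values given here, with no measured step to lean on, the change is expected to stay within the scatter of this assay, with no clear direction. The step that this estimate means, an at least 1.2-fold lower number from compound 2 to compound 3 (0.08 log units; that floor lies within the scatter), is expected to be none beyond the scatter. Compound 3 is therefore expected to show about 1500000 nM, somewhere between 300000 nM and 3500000 nM, with a good chance that it too is reported only as a limit.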

Compound 3, half-maximal cytotoxic concentration: > 1870000 nM
Compound 3: only a limit was reported; the forecaster's own chance of this, stated with the estimate: 70%; middle value at least 1.2-fold (0.09 log units) away from the limit.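

In this assay, compound 2 and compound 3 each give only a limit of the assay, not a number. The step from compound 2 to compound 3 therefore cannot be read. The compounds shown leave open at what concentration either compound stops being tolerated, and whether pyridin-4-yl in place of thiophen-2-yl changes that concentration at all.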